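Chloro in Place of Methoxy on the Amide Arm

A few compounds are considered here, and "the series" means these few. Any claim that something is new, unique, unknown or untested is made for them only; others in the source may bear on it.

Of the compounds shown here, two sharing one core have been measured in a functional assay on L1210 cells (Mus musculus) for cytotoxicity; a lower number here means a stronger inhibitor, a higher number a weaker inhibitor. Compound 1 `Cc1cccc(C)c1NC(=O)/C=C/C(=O)N1C/C(=C\c2ccccc2)C(=O)/C(=C/c2ccccc2)C1` gives 22000 nM. Going by the values given here, compound 2 `COc1ccc(NC(=O)/C=C/C(=O)N2C/C(=C\c3ccccc3)C(=O)/C(=C/c3ccccc3)C2)cc1` gives 6800 nM, the lowest of the two numbers; the only neighbour is compound 1, and the step of a 3.2-fold lower number from compound 1 to compound 2 (0.51 log units; beyond the scatter) came from replacing the 2,6-dimethylphenyl with a 4-methoxyphenyl on the amide-type nitrogen.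

Compound 3 `O=C(/C=C/C(=O)N1C/C(=C\c2ccccc2)C(=O)/C(=C/c2ccccc2)C1)Nc1ccc(Cl)cc1` keeps that amide arm but changes the group on the aromatic ring: chloro in place of methoxy on an aromatic carbon. Among the compounds with values here, no measured step shows exactly this exchange, so nothing tells directly how this assay responds to it. Within the data shown here, the one step on hand, a 3.2-fold lower number from compound 1 to compound 2 (0.51 log units; beyond the scatter), shows that changing the group on this aryl ring can shift the number modestly, but it does not say in which direction a chloro would move it. A small change, likely within the scatter or just beyond it, is therefore expected, and the step of a 1.2-fold lower number from compound 2 to compound 3 (0.09 log units; within the scatter) is the estimate. For compound 3 the expected value in this assay is 5500 nM, with a range from 2000 nM to 15000 nM.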

Compound 3, half-maximal inhibitory concentration: 7800 nM
The estimate for compound 3 lay 1.4-fold (0.15 log units) below the measured number; the measured number falls inside the stated range.
By their numbers in this assay, from the lowest: compounds 2 and 3 (each within the scatter of the next); then compound 1.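

In this assay, the exchange of methoxy, with its one hydrogen-bond acceptor, for chloro, with none, gives a 1.1-fold higher number from compound 2 to compound 3 (0.06 log units; within the scatter), so compound 2 and compound 3 cannot be told apart at this position of the ring. The earlier step came from a single pair, but the new result gives a second aryl group that reads clearly differently from the 2,6-dimethylphenyl: a 2.8-fold lower number from compound 1 to compound 3 (0.45 log units; beyond the scatter). Compound 2 and compound 3 therefore agree in their distance from compound 1, although their 4-methoxyphenyl and 4-chlorophenyl groups carry different atoms. No measurement at hand accounts for why the two groups read alike.

As far as these compounds go, whether this tolerance holds beyond these two groups stays open, since an amine or a carboxylic acid at the same place on the ring could read quite differently. The step from the 2,6-dimethylphenyl also changes the number of groups on the ring and their placement at once, and a 4-methylphenyl would be needed to pull those two changes apart.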